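Lengthening the Chain on a Shared Core: Compound 3

The source may hold more compounds than are shown below. What is called first, only, known or untested is meant among the compounds shown, and "the series" means these compounds.

Measured compounds:
compound 1, `Cc1ccc(=O)n(CCCCC(=N)S)n1`: 29.5%
compound 2, `N=C(S)Cn1nc(-c2ccccc2)ccc1=O`: 5.5%

In a functional assay on the whole organism (stomach) for inhibition, with Rattus norvegicus as the target, at a dose of 100 mg/kg by the intraduodenal route (a higher number here means more inhibition at the dose given (going by the name of the read-out), a lower number less inhibition), compound 1 gives 29.5%. In this assay compound 2 gives 5.5%, the lowest of the two numbers, and its gap to compound 1 lies beyond the usual scatter of such measurements.

The step under study leads from compound 2 to compound 3, `N=C(S)CCCCn1nc(-c2ccccc2)ccc1=O`, which has not yet been measured in this assay. Between the two structures there is one change: a group of 6 heavy atoms (4 carbon, 1 nitrogen, 1 sulfur; no ring) in place of a group of 3 heavy atoms (1 carbon, 1 nitrogen, 1 sulfur; no ring), on a saturated chain carbon bound to an aromatic nitrogen.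

For the measured compounds named here, no measured pair shows this step, so nothing about its size is known from the data. What can be said is that compound 1, which also bears the longer chain, gives 29.5%, whereas compound 2 with the shorter chain gives 5.5%. On this basis the step from compound 2 to compound 3 is expected to raise inhibition, by a number 16.5 percentage points higher from compound 2 to compound 3 (beyond the scatter). For compound 3 the estimated result in this assay is 22%, with a range from 5% to 42%.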

Compound 3, a percentage reported as inhibition, in the whole organism at one dose (the size of the read-out at that dose, not a potency): 33.8%
For compound 3 the middle estimate is 11.8 percentage points below the measured one; measured number inside the range.
By their numbers in this assay, from the lowest: compound 2; then compounds 1 and 3 (each within the scatter of the next).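

For the compounds shown here, with compound 3, the longer chain in place of the shorter one, on a saturated chain carbon bound to an aromatic nitrogen, can be read as a single change for the first time: in this assay it gives a number 28.3 percentage points higher from compound 2 to compound 3 (beyond the scatter). Compound 1 and compound 2 differ in two places and could not isolate this change, whereas the measured step shows that chain length alone matters with phenyl on the core. The second step, phenyl in place of methyl on an aromatic carbon with the longer chain kept, gives a number 4.3 percentage points higher from compound 1 to compound 3 (within the scatter), so this assay does not separate these two groups on that chain. Nothing in the data gives a reason for either result.

The compounds shown leave open whether a still longer chain would extend the rise or reverse it, and whether an amine or a carboxylic acid at the end of the chain would keep the inhibition. They also leave open whether phenyl and methyl stay level on the shorter chain, and, with every reading taken at one dose, how the compounds compare in potency.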